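A Sec-Butyl Exchange on Compound 2

This account rests on a few compounds, and the source may have more. Where it says the series, first, only, none or still open, it means among the compounds named here.

Among the compounds with values here, only two compounds have been measured so far. In a functional assay on RAW264.7 cells (Mus musculus), read by Griess assay, with a stated time of 24 h (a higher number here means a weaker inhibitor, a lower number a stronger inhibitor), compound 1 (`C/C=C(\C)C(=O)O[C@@H]1[C@H](O)[C@@H](OC(=O)C(C)CC)[C@@H](O)[C@H](OC(=O)/C(=C/C)CO)[C@H]1OC(=O)/C(=C/C)CO`) gives 20300 nM, while compound 2 (`C/C=C(\C)C(=O)O[C@@H]1[C@@H](O)[C@@H](OC(=O)C(C)CC)[C@H](OC(=O)/C(=C/C)CO)[C@@H](OC(=O)/C(=C/C)CO)[C@@H]1O`) gives 124000 nM. Compound 2 therefore has the higher of the two numbers and is the weaker inhibitor, with a gap to compound 1 that lies beyond the usual scatter of repeated measurements.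

Compound 3 (`C/C=C(\CO)C(=O)O[C@H]1[C@H](OC(=O)C(C)CC)[C@H](O)[C@@H](OC(=O)C(C)CC)[C@@H](O)[C@@H]1OC(=O)/C(=C/C)CO`) has not yet been measured. Its difference from compound 2 is sec-butyl in place of 1-methylprop-1-en-1-yl on a carbonyl carbon, with sec-butyl in place of 1-methylprop-1-en-1-yl on a carbonyl carbon. Within the data shown here, no step between measured compounds shows what such an exchange does, so the expectation in this assay rests on thin evidence. Compound 2, at 124000 nM, holds the upper end of the measured numbers, and compound 1, at 20300 nM, marks the lower end. A modest move toward the lower end is therefore expected. The step expected is a 2.1-fold lower number from compound 2 to compound 3 (0.32 log units; beyond the scatter). For compound 3 the estimated value is 60000 nM, with an expected range from 15000 nM to 180000 nM.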

Compound 3, half-maximal inhibitory concentration: 62900 nM
Beside the measured number, compound 3's estimate is 1.0-fold (0.02 log units) below it; low and high end bracket the measured number.
By their numbers in this assay, from the lowest: compound 1; then compounds 3 and 2 (each within the scatter of the next).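

Within the data shown here, this is the first readable step for the exchange of 1-methylprop-1-en-1-yl for sec-butyl on a carbonyl carbon whose other neighbour is oxygen next to a carbonyl group: in this assay, the change gives a 2.0-fold lower number from compound 2 to compound 3 (0.29 log units; within the scatter), so the loss of that double bond leaves the number unresolved from the usual variation between repeats. The same listed exchange, read against the other measured compound, gives a 3.1-fold higher number from compound 1 to compound 3 (0.49 log units; beyond the scatter), which shows that one exchange can yield steps on either side of the scatter, and that its size in this assay depends on the compound it starts from, so no single value can yet be assigned to it. No independent measurement on hand bears on these two steps, and they remain bare numbers.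

The compounds shown leave open whether any other group on this carbonyl carbon, such as a longer chain like n-hexyl, a phenyl ring or an amine, would move the number beyond the scatter from compound 2. They also leave open whether the exchange would behave alike on further compounds, since only these two steps carry it.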